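A chloro swap at the limit of a cytotoxicity read-out

The compounds below may be only part of what the source reports. "The series", "measured", "known", "first", "only" and "open" are said of these compounds alone.

Values in an ADME assay on BJ cells (Homo sapiens) for cytotoxicity, with a stated time of 72 h (on this read-out lower numbers stand for an effect already at smaller amounts and higher numbers for an effect only at larger amounts of compound), each one a limit:
Compound 1 `C=C[C@@](C)(/C=C/c1ccc(OC)cc1)CCC=C(C)C`: > 36600 nM
Compound 2 `C=C[C@@](C)(/C=C/c1ccc(Nc2ccc(OC)c(OC)c2)cc1)CCC=C(C)C`: > 36600 nM
Compound 3 `C=C[C@@](C)(/C=C/c1ccc(Nc2ccc(OC)c(F)c2)cc1)CCC=C(C)C`: > 36600 nM

Compound 3 stands at a limit of this assay with > 36600 nM and not at a number. Compound 4 `C=C[C@@](C)(/C=C/c1ccc(Nc2ccc(Cl)c(F)c2)cc1)CCC=C(C)C` carries chloro in place of methoxy on an aromatic carbon. Going by the values given here, only one measured step bears on this, a step that the two limits leave unreadable from compound 2 to compound 3, which also replaces a methoxy and has no readable size. The series offers only the limit of > 36600 nM in this assay, at which 3 of the 3 values shown sit, and so no size to carry over. The expected step is a step that the limit leaves unreadable from compound 3 to compound 4 and none beyond the scatter is expected in either direction. Compound 4 is expected near 40000 nM within an estimated range from 15000 nM to 80000 nM and may well report as a limit again.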

Compound 4, half-maximal effective concentration: > 36600 nM
Compound 4 gave a limit, no number; the forecaster's own chance of this, stated with the estimate: 80%; the middle value lies beyond the limit too.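

No step can be read from compound 3 to compound 4 or from compound 1 to compound 4, as each value is only a limit: the limit of > 36600 nM in this assay, at which 4 of the 4 values shown sit.

The compounds shown leave open at what concentration any of them would reach a half-maximal effect, and so whether chloro and methoxy differ on this read-out.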